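Chain stereocentre inversion from compound 2 to compound 3

The source may hold more compounds than are shown below. What is called first, only, known or untested is meant among the compounds shown, and "the series" means these compounds.

In a functional assay on NCI-H460 cells (Homo sapiens) for antiproliferative activity, with a stated time of 72 h (on this read-out lower numbers stand for stronger inhibition and higher numbers for weaker inhibition), compound 1 (`C=CC[C@H]1C[C@]2([C@H](C)Cc3cc(F)c(OC)cc3F)OCOC2=CC1=O`) reads 35 nM and compound 2 (`C=CC[C@H]1C[C@]2([C@@H](C)Cc3cc(O)c(OC)cc3F)OCOC2=CC1=O`) reads 33 nM on the same scale. These two values lie within the scatter of each other, so compound 2 stands level with compound 1 and no order can be read between them.

The move to compound 3 (`C=CC[C@H]1C[C@]2([C@H](C)Cc3cc(O)c(OC)cc3F)OCOC2=CC1=O`) is one of configuration alone (the two compounds have the same atoms and bonds and differ only in configuration as drawn: 1 of 3 stereo elements differ; a stereocentre at a saturated chain carbon is drawn S in compound 2 and R in compound 3), with the same atoms and bonds in both compounds. For the measured compounds named here, no measured pair in this small set isolates such an inversion, so the data give neither a size nor a direction for it. Going by the values given here, the only direct anchor is compound 2 at 33 nM in this assay and the working expectation stays close to it, with no shift beyond the scatter in either direction. The expected step of a 1.2-fold higher number from compound 2 to compound 3 (0.08 log units; within the scatter) is small, and the estimate carries a wide range to allow for a real loss or gain. For compound 3 the estimated value is 40 nM with an expected range from 12 nM to 150 nM in this read-out.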

Compound 3, half-maximal inhibitory concentration: 15 nM
Compound 3: the middle estimate sits 2.7-fold (0.43 log units) above what was measured, within the range that was stated.
By their numbers in this assay, from the lowest: compound 3; then compounds 2 and 1 (each within the scatter of the next).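

In this assay, the chain stereocentre now proves to be a position that registers in its own right: inversion from S to R gives a 2.2-fold lower number from compound 2 to compound 3 (0.34 log units; beyond the scatter), and this modest step can be assigned to that carbon alone because no other feature changes: the fact that compounds 2 and 3 differ only in the configuration as drawn. With the chain stereocentre drawn the same way, hydroxy in place of fluoro on an aromatic carbon gives a 2.3-fold lower number from compound 1 to compound 3 (0.37 log units; beyond the scatter), so the aromatic substituent also registers in this assay. Compound 1 and compound 2 differ in both of these places, so their level readings cannot be taken to show that either change is without effect.

The compounds shown leave open whether the inversion gives a step of similar size and direction with fluoro rather than hydroxy on that aromatic carbon, as the only measured inversion pair carries hydroxy. They also leave open how an amine or a carboxylic acid in place of the hydroxy would read, and whether a longer chain in place of the methyl on the stereocentre would keep the gain seen with the R configuration.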